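A few compounds are considered here, and "the series" means these few. Any claim that something is new, unique, unknown or untested is made for them only; others in the source may bear on it.

In a functional assay on A-375 cells (Homo sapiens) for activation, with a stated time of 3 days (on this read-out lower numbers stand for an effect already at smaller amounts and higher numbers for an effect only at larger amounts of compound), compound 1 `O=C(Nc1ccc(-c2cscn2)cc1)C1CCCN(S(=O)(=O)c2ccc(F)c(F)c2)C1` gives > 20000 nM, which is a limit of the assay and not a number. Compound 2 `O=C(Nc1ccc(-c2cscn2)cc1)[C@@H]1CCCN(Cc2ccc(F)c(F)c2)C1` gives 4000 nM and compound 3 `O=C(Nc1ccc(-c2cscn2)cc1)C1CCCN(Cc2cccc(F)c2)C1` gives 5000 nM, and these two values lie within the scatter of each other. Compound 4 `O=C(Nc1ccc(-c2cscn2)cc1)C1CCCN(Cc2ccc3cn[nH]c3c2)C1` departs from compound 3 at one place: 1H-indazol-6-yl in place of 3-fluorophenyl on a saturated chain carbon bound to an amine nitrogen in a ring. Here 1H-indazol-6-yl stands in place of 3-fluorophenyl on a saturated chain carbon bound to an amine nitrogen in a ring. Going by the values given here, no measured pair covers this exchange, so only a modest move toward a lower number in this assay is expected, and a result within the scatter would be unsurprising. The expected step is a 2.0-fold lower number from compound 3 to compound 4 (0.30 log units; within the scatter). For compound 4 the estimate is 2500 nM, with an expected range of 500 nM to 10000 nM.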

Compound 4, half-maximal effective concentration: > 20000 nM
Compound 4 ended at the assay's limit (the forecaster's own chance of this, stated with the estimate: 10%); middle value at least 8.0-fold (0.90 log units) away from the limit.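

In this assay, going by these compounds alone, 1H-indazol-6-yl in place of 3-fluorophenyl on a saturated chain carbon bound to an amine nitrogen in a ring gives an at least 4.0-fold higher number from compound 3 to compound 4 (0.60 log units; beyond the scatter) and is the first readable step at this place. This exchange moves the number up, not down. The step is only a lower bound because compound 4 sits at a limit of the assay and not at a number: the limit of > 20000 nM in this assay, at which 2 of the 4 values shown sit.

Going by these compounds, it stays open whether the added ring or its nitrogen atoms carry this shift. A pyridin-3-yl or an unsubstituted phenyl group at the same place would help to separate the two.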